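A few compounds are considered here, and "the series" means these few. Any claim that something is new, unique, unknown or untested is made for them only; others in the source may bear on it.

Two pairs of compounds share the same small swap of one halogen for another. Compound 1 `Cc1cccc2c(-c3ccc4ccc(F)cc4n3)c[nH]c12` and compound 3 `Cc1cccc2c(-c3ccc4ccc(Cl)cc4n3)c[nH]c12` make up the measured pair, with the change (chloro in place of fluoro on an aromatic carbon). Compound 2 `Fc1cc(Cl)cc2c(-c3ccc4ccccc4n3)c[nH]c12` and the not yet measured compound 4 `Clc1cc(Cl)c2[nH]cc(-c3ccc4ccccc4n3)c2c1` make up the second pair, with the change (chloro in place of fluoro on an aromatic carbon). How the core of compound 2 differs from the core of compound 1 is not broken down here.

In an ADME assay on microsomes from liver (Homo sapiens) for metabolic stability, using NADPH, with a stated time of 40 min, tested at 2 uM (on this read-out lower numbers stand for a shorter-lived compound and higher numbers for a longer-lived compound), compound 1 gives 0.883 h, and compound 3 gives 1.48 h, so that a 1.7-fold higher number from compound 1 to compound 3 (0.22 log units; within the scatter). In this assay compound 2 gives 0.633 h; its number and that of compound 1 lie within the usual scatter of each other, while its gap to compound 3 lies beyond it.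

The two swaps are the same kind of change, not the same: in the first pair the place is meta to a fused ring and para to a fused ring, whereas in the second it is ortho to a fused ring, meta to a chloro group and meta to a fused ring. For the measured compounds named here, with only one measured example of the swap, the expectation for compound 4 rests on that single step: the step from compound 2 to compound 4 is expected to be about a 1.6-fold higher number from compound 2 to compound 4 (0.20 log units; within the scatter) because the measured pair showed a 1.7-fold higher number from compound 1 to compound 3 (0.22 log units; within the scatter). On that basis compound 4 is estimated to give 1 h in this assay, with a range from 0.5 h to 2 h.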

Compound 4, half-life: 2.57 h
For compound 4 the middle estimate is 2.6-fold (0.41 log units) below the measured one, outside the stated range (above it).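

In this assay, putting chloro in place of fluoro on the second core gives a 4.1-fold higher number from compound 2 to compound 4 (0.61 log units; beyond the scatter), a step large enough to stand out from the ordinary spread of repeat measurements. Set beside the same swap on the core of compound 1, this step cannot be told apart from the earlier one: the same change on two cores in this assay, a 1.7-fold higher number (0.22 log units; within the scatter) from compound 1 to compound 3 and a 4.1-fold higher number (0.61 log units; beyond the scatter) from compound 2 to compound 4, 2.4-fold (0.38 log units) apart, within the scatter of two such steps. For the compounds shown here, the two results are therefore compatible with a swap that carries over from one core to the other, but they do not establish it, since there are only two pairs, the halogen sits at a different place in each, and only the step on the second core lies clear of the scatter on its own.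

On these data alone, it remains open whether the swap would behave the same way on further cores, or at other places on these same cores. The compounds shown also give no guide to how a group other than these two halogens, such as bromo, methoxy, a nitrile or an amine, would fare at the place where chloro and fluoro were exchanged.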